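Dimethylation of a Bicyclic Amine and Its Partition Coefficient

The compounds below may be only part of what the source reports. "The series", "measured", "known", "first", "only" and "open" are said of these compounds alone.

The account concerns compound 1 `CNC1CC2CCC1(C)C2(C)C`, a secondary amine on a methylated bicyclic core. Within the data shown here, in a physicochemical assay for lipophilicity (a lower number here means a more polar compound, a higher number a more lipophilic compound), compound 1 gives 3.53, and this is the only number recorded for it. A second measured compound, compound 2 `CNC1CC2CCC1C2`, carries the same methylamino group on an unsubstituted core; in this assay compound 2 gives 1.97; 1.97 (2 entries), with two entries agreeing. Among the measured compounds shown here, no step between these two has been worked out, so only the two values themselves are noted.

The step of interest leads from compound 1 to compound 3 `CN(C)C1CC2CCC1(C)C2(C)C`: methyl in place of hydrogen on an amine nitrogen, which reads, one bond further out, as methylamino to dimethylamino. For the measured compounds named here, no measured pair shows this change, so the expectation rests on the added methyl alone. The step of a number 0.42 log units higher from compound 1 to compound 3 (beyond the scatter) is expected to be modest and upward, somewhat beyond the scatter. For compound 3 a value of 3.95 is estimated, between 3.55 and 4.4.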

Compound 3, partition coefficient: 3.96
Beside the measured number, compound 3's estimate is 0.01 log units below it, and the stated range covers the measured number.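

In this assay, methyl in place of hydrogen on an amine nitrogen gives a number 0.43 log units higher from compound 1 to compound 3 (beyond the scatter) and so turns the expectation for this change into a measured step. Compounds 1 and 2 differ in more than one place and could not isolate any single change, whereas this pair differs only on the nitrogen, whose other neighbours are a saturated chain carbon and a saturated ring carbon. Nothing shown here accounts for the size of the step.

This single pair leaves open whether methylamino to dimethylamino would give a step of similar size on the unsubstituted core of compound 2. It also leaves open how a longer chain on the same nitrogen, such as ethyl or propyl, or an acetyl group there, would read in this assay.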